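Tert-butoxycarbonyl on the amine of compound 3

A few compounds are considered here, and "the series" means these few. Any claim that something is new, unique, unknown or untested is made for them only; others in the source may bear on it.

compound 1 `Oc1ccc(CN(CCN2CCCC2)Cc2ccc(O)c3ncccc23)c2cccnc12` gives 0.2 uM
compound 2 `Cc1ccc(CNCc2ccc(O)c3ncccc23)cc1` gives > 10 uM as a limit
compound 3 `Oc1ccc(CNCc2ccc(C(F)(F)F)cc2)c2cccnc12` gives > 10 uM as a limit

All three were tested in a functional assay on U-87MG ATCC cells (Homo sapiens) for antiproliferative activity, with a stated time of 3 days (a lower number here means that less compound is needed, a higher number that more compound is needed for the effect), and the results for compound 2 and compound 3 are limits. Compound 3 has only the limit (> 10 uM) as its result. Compound 4 `CC(C)(C)OC(=O)N(Cc1ccc(C(F)(F)F)cc1)Cc1ccc(O)c2ncccc12` carries tert-butoxycarbonyl in place of hydrogen on an amine nitrogen of compound 3. Within the data shown here, the one measured step (a step that the two limits leave unreadable from compound 2 to compound 3) concerns trifluoromethyl in place of methyl on an aromatic carbon, has no readable size and does not touch this nitrogen. In this assay no step beyond the scatter is therefore expected, and the estimated step (a step that the limit leaves unreadable from compound 3 to compound 4) has no measured direction behind it. Compound 4 is expected at 15 uM within an estimated range from 6 uM to 40 uM in this assay.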

Compound 4, concentration for half-maximal effect: 2 uM
Compound 4: middle estimate off by 7.5-fold (0.88 log units), on the high side; the measured number lies below the stated range.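

In this assay, tert-butoxycarbonyl in place of hydrogen on this amine nitrogen gives an at least 5.0-fold lower number from compound 3 to compound 4 (0.69 log units; beyond the scatter). Among these compounds, this is the first readable step, and it shows that the number responds to a change at this nitrogen, which the earlier compounds could not show. On these data alone, its true size remains unknown, since the result for compound 3 is a limit: the limit of > 10 uM in this assay, at which 2 of the 4 values shown sit.

As far as these compounds go, it remains open whether methyl or acetyl on this nitrogen would give a similar step. From the compounds shown here alone, it is also open whether a basic amine chain would do so.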